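Furan acid series: aryl swap from compound 2 to compound 3

The source may report more compounds than this note shows. Statements on the series, on what has been measured and on what is new or still open speak of the compounds shown alone.

Two compounds of the series carry numbers in an assay on cells for displacement of a labelled ligand from prostaglandin E2 receptor EP4 subtype (Homo sapiens), read by scintillation counting; a higher number here means a weaker inhibitor, a lower number a stronger inhibitor. Compound 1 `Cc1oc(CC(=O)O)cc1COc1ccc(-c2ccccc2)cc1` gives 80 nM in this assay. Compound 2 `COc1ccccc1-c1ccc(OCc2cc(C(=O)O)oc2C)cc1` gives 1600 nM in this assay, the higher of the two numbers, and the gap between compound 1 and compound 2 lies beyond the scatter. Among the compounds with values here, no single-point step between measured compounds is available, since compound 1 and compound 2 differ in more than one place.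

Compound 3 `Cc1oc(C(=O)O)cc1COc1ccc(-c2ccc(CO)cc2)cc1` keeps the core of compound 2 and changes only the distal aromatic group: 4-(hydroxymethyl)phenyl in place of 2-methoxyphenyl on an aromatic carbon. The change sits on an aromatic carbon of a six-membered aromatic ring of carbon only, para to a large group.

Within the data shown here, no measured pair informs this exact change. Among the measured compounds shown here, the only comparison available, compound 1 against compound 2, shows that the lower number sits with the compound lacking the 2-methoxyphenyl, which gives weak support for a modest downward step. The step from compound 2 to compound 3 is therefore expected to be a 2.0-fold lower number from compound 2 to compound 3 (0.30 log units; within the scatter), small and within or near the scatter. Compound 3 is estimated at 800 nM, with a range from 200 nM to 3000 nM.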

Compound 3, inhibition constant: 3000 nM
Estimate against measurement, compound 3: 3.8-fold (0.57 log units) below, and the stated range covers the measured number.
By their numbers in this assay, from the lowest: compound 1; then compounds 2 and 3 (each within the scatter of the next).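

In this assay, placing 4-(hydroxymethyl)phenyl in place of 2-methoxyphenyl on an aromatic carbon gives a 1.9-fold higher number from compound 2 to compound 3 (0.27 log units; within the scatter), the first one-place step read in this series. At this position, the exchange therefore separates compound 2 and compound 3 by no more than the scatter, even though the entering group carries a hydrogen-bond donor that the leaving group lacks and the substituent stands on a different ring position. Loss of the 2-methoxyphenyl alone thus brings no step beyond the scatter in this pair, and nothing measured here offers an explanation for the result.

Open, from the compounds shown here alone, is whether an aminomethyl group, a carboxylic acid or a longer hydroxyalkyl chain on the same distal ring would move the number beyond the scatter in this assay, or whether this position stays as flat as this single step suggests. Also open, going by these compounds, is how much of the gap between compound 1 and compound 2 belongs to the distal aromatic group and how much to the other places in which those two compounds differ, since one step at one position cannot divide it.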